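Two Tails Compared Before a Third Is Measured

The source may hold more compounds than are shown below. What is called first, only, known or untested is meant among the compounds shown, and "the series" means these compounds.

Of the compounds shown here, two have been tested in a functional assay on the whole organism with Rattus norvegicus as the target, at a dose of 100 mg/kg; a lower number here means less inhibition, a higher number more inhibition at the dose given (going by the name of the read-out). Compound 1 `C/N=C(/NC#N)NCCCn1nc(-c2ccccc2)ccc1=O` gives 40.5%. Compound 2 `CCC/N=C(/NC#N)NCCCCn1nc(-c2ccccc2)ccc1=O` gives 26.3%, the lowest of the two numbers, with compound 1 standing higher by a margin beyond the usual scatter. Compound 3 `CC/N=C(\S)NCCCCn1nc(-c2ccccc2)ccc1=O` has not yet been measured. Compared with compound 2, it carries a group of 5 heavy atoms (3 carbon, 1 nitrogen, 1 sulfur; no ring) in place of a group of 8 heavy atoms (5 carbon, 3 nitrogen; no ring), on an amine nitrogen. Going by the values given here, no measured pair shows the effect of such a change, so the expected step in this assay is small and uncertain, a number 6.7 percentage points higher from compound 2 to compound 3 (within the scatter), leaning slightly upward. Compound 3 is estimated to give 33%, within a range from 10% to 58%.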

Compound 3, a percentage reported as inhibition, in the whole organism at one dose (the size of the read-out at that dose, not a potency): 67.7%
The estimate for compound 3 lay 34.7 percentage points below the measured number, and the stated range ends below it.
By their numbers in this assay, from the lowest: compound 2; then compound 1; then compound 3.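

Swapping the group of 8 heavy atoms for the sulfur-containing group of 5 heavy atoms on the amine nitrogen gives a number 41.4 percentage points higher from compound 2 to compound 3 (beyond the scatter) in this assay, so a change at this position can move the read-out a long way. The comparison made on the saturated chain carbon points the same way, with a number 27.2 percentage points higher from compound 1 to compound 3 (beyond the scatter) in this assay. Nothing measured here explains the rise.

Still open, going by these compounds, is whether a urea, with oxygen in place of the sulfur, would keep this level. Also open, on these data alone, is how a longer chain on the sulfur-containing group would read.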